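Carbamoyl on the piperazine: stability of compound 4

The source may hold more compounds than are shown below. What is called first, only, known or untested is meant among the compounds shown, and "the series" means these compounds.

Compound 3 `c1ccc2c(c1)CN[C@@H](CN(CCN1CCNCC1)[C@H]1CCCc3cccnc31)C2` is the most stable of the three measured compounds in an ADME assay on microsomes from liver (Homo sapiens) for metabolic stability, read by LC-MS, with a stated time of 10 min, tested at 0.5 uM; on this read-out lower numbers stand for a less stable compound and higher numbers for a more stable compound: compound 3 gives 96%. Its nearest neighbour is compound 1 `c1ccc2c(c1)CN[C@@H](CN(CC1CCNCC1)[C@H]1CCCc3cccnc31)C2`, for which compound 1 gives 86%, a difference within the scatter. Compound 2 `c1cnc2c(c1)CCC[C@@H]2N(CCCN1CCNCC1)Cc1nc2ccccc2[nH]1`, which differs from compound 3 in more than one place, stands furthest away, since compound 2 gives 63%, a gap beyond the scatter.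

Compound 4 `NC(=O)N1CCN(CCCN(C[C@H]2Cc3ccccc3CN2)[C@H]2CCCc3cccnc32)CC1` differs from compound 3 by (4-carbamoylpiperazin-1-yl)methyl in place of piperazin-1-yl on a saturated chain carbon, two bonds along the chain from an amine nitrogen. Among the measured compounds shown here, the one measured step that bears on this is the change at the same region of the chain from compound 1 to compound 3, where a number 10 percentage points higher from compound 1 to compound 3 (within the scatter) was seen; a replacement of one basic ring by another there did not move the read-out beyond the scatter. For the measured compounds named here, no measured compound carries a carbamoyl group, so the effect of that addition is not known from the series.

Given that, compound 4 is expected to stay close to compound 3, with a step of a number 8 percentage points lower from compound 3 to compound 4 (within the scatter), which is within the scatter. The estimate for compound 4 is 88%, with a range from 70% to 98%.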

Compound 4, percent of the compound remaining: 79%
Compound 4: middle estimate off by 9 percentage points, on the high side; low and high end bracket the measured number.
By their numbers in this assay, from the lowest: compound 2; then compounds 4, 1 and 3 (each within the scatter of the next, the first and the last beyond it).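

In this assay this place on the chain now shows a step beyond the scatter: a number 17 percentage points lower from compound 3 to compound 4 (beyond the scatter) is seen on going to (4-carbamoylpiperazin-1-yl)methyl, while the earlier exchange of piperidin-4-yl for a piperazine group, a number 10 percentage points higher from compound 1 to compound 3 (within the scatter) as printed, stayed within it. The read-out here therefore responds modestly to the entering group, although the reach of that response is limited: a number 7 percentage points lower from compound 1 to compound 4 (within the scatter) remains within the scatter, so compound 4 is set apart from compound 3 only and not from compound 1. Nothing at hand gives a reason for the lower number at this position.

The step from compound 3 to compound 4 changes two things at once, the carbamoyl group and the extra methyl link named in (4-carbamoylpiperazin-1-yl)methyl, and the compounds shown do not separate the two. A piperazine carrying an acetyl group or a plain methyl group on the same chain as compound 4 would show whether the carbonyl, the amide hydrogens or the chain alone goes with the change in this read-out.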